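The source may hold more compounds than are shown below. What is called first, only, known or untested is meant among the compounds shown, and "the series" means these compounds.

Compound 3 `Fc1ccccc1Cn1cnc2c(NC3CCC3)ncnc21` gives 33 mg/kg in a functional assay on the whole organism with Rattus norvegicus as the target, in the maximal electroshock model (a lower number here means that less compound is needed, a higher number that more compound is needed for the effect), the highest of the two numbers at hand; compound 1 `CC(C)Nc1ncnc2c1ncn2Cc1ccccc1F` gives 5.8 mg/kg. Compound 2 `CC(C)(C)Nc1ncnc2c1ncn2Cc1ccccc1F` gives only a limit, > 50 mg/kg. Compound 4 `CCN(C)c1ncnc2c1ncn2Cc1ccccc1F` carries ethyl(methyl)amino in place of cyclobutylamino on an aromatic carbon, so the ring and the hydrogen-bond donor both go. Every measured step moves the group on that nitrogen: a 5.7-fold higher number from compound 1 to compound 3 (0.76 log units; beyond the scatter), an at least 8.6-fold higher number from compound 1 to compound 2 (0.93 log units; beyond the scatter), and an at least 1.5-fold lower number from compound 2 to compound 3 (0.18 log units; that floor lies within the scatter). Within the data shown here, none removes the donor, so no step bears on it directly; together they show only that changes at this nitrogen shift the number by modest amounts. The number for compound 4 is therefore expected to sit near or somewhat above that of compound 3, a step of a 1.2-fold higher number from compound 3 to compound 4 (0.08 log units; within the scatter). Compound 4 is estimated at 40 mg/kg, within 12 mg/kg to 120 mg/kg, with a real chance of only a limit.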

Compound 4, dose for half-maximal effect: 2.9 mg/kg
Estimate against measurement, compound 4: 14-fold (1.14 log units) above; measured number below the stated range.
By their numbers in this assay, from the lowest: compounds 4 and 1 (each within the scatter of the next); then compound 3. At a limit, above all of these: compound 2.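

A group with no hydrogen-bond donor on this nitrogen still gives a low number in this assay: ethyl(methyl)amino in place of cyclobutylamino gives an 11-fold lower number from compound 3 to compound 4 (1.06 log units; beyond the scatter), so within these compounds the donor is not needed. Against isopropylamino, the same group gives a 2.0-fold lower number from compound 1 to compound 4 (0.30 log units; within the scatter), which leaves the two unordered. Against a limit, the step reads an at least 17-fold lower number from compound 2 to compound 4 (1.23 log units; beyond the scatter), a floor only: the limit of > 50 mg/kg in this assay, at which 1 of the 4 values shown sits.

The ring and the donor leave together in the step from cyclobutylamino, so their shares stay unseparated. From the compounds shown here alone, whether dimethylamino, diethylamino or a pyrrolidine ring on this aromatic carbon keeps the number low remains open.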